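A sulfonamide swap on a weakly cytotoxic compound

The source may report more compounds than this note shows. Statements on the series, on what has been measured and on what is new or still open speak of the compounds shown alone.

For the measured compounds named here, in a functional assay on MCF7 cells (Homo sapiens) for cytotoxicity, read by sulforhodamine B assay, with a stated time of 72 h (a higher number here means a weaker inhibitor, a lower number a stronger inhibitor), compound 1 `Cc1cc(NS(=O)(=O)c2ccc(NCc3coc4ccccc4c3=O)cc2)no1` gives 34500 nM as the only numerical value so far. Compound 2 `O=C1/C(=C/c2coc3ccccc3c2=O)N=C(c2ccc(Cl)cc2)N1c1ccc(S(=O)(=O)Nc2ncccn2)cc1` stands at > 100000 nM and this value is a limit of the assay. Compound 3 `O=c1c(CNc2ccc(S(=O)(=O)Nc3ccccn3)cc2)coc2ccccc12` has pyridin-2-yl in place of 5-methyl-1,2-oxazol-3-yl on a sulfonamide nitrogen and is otherwise unchanged. Going by the values given here, no measured step shows the effect of this change. The expected step of a 1.0-fold higher number from compound 1 to compound 3 (0.01 log units; within the scatter) in this assay is no larger than the scatter, with neither direction favoured. Compound 3 is estimated at 35000 nM with 12000 nM to 100000 nM as its expected range.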

Compound 3, half-maximal inhibitory concentration: > 100000 nM
Compound 3 was reported as a limit; the forecaster's own chance of this, stated with the estimate: 15%; middle value at least 2.8-fold (0.45 log units) away from the limit.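

In this assay, for the compounds shown here, putting pyridin-2-yl in place of 5-methyl-1,2-oxazol-3-yl on the sulfonamide nitrogen gives the first measured step at this position: an at least 2.8-fold higher number from compound 1 to compound 3 (0.46 log units; beyond the scatter). The group on this nitrogen therefore does affect the read-out, and this change moves it towards a weaker inhibitor. The value of compound 3 is a limit, so the step gives only a minimum size: the limit of > 100000 nM in this assay, at which 2 of the 3 values shown sit.

From the compounds shown here alone, the full size of the step remains open. So does what a short alkyl chain or a plain phenyl ring would give on this nitrogen.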